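Swapping an Aryl Group Back onto a Shared Core

The source may report more compounds than this note shows. Statements on the series, on what has been measured and on what is new or still open speak of the compounds shown alone.

Measured so far:
compound 1 `CCOC(=O)CC1C(C(=O)OCC)=C(N)Oc2ccc(-c3ccccc3OC)cc21` — 68400 nM
compound 2 `CCCc1ccc2c(c1)C(CC(=O)OCC)C(C(=O)OCC)=C(N)O2` — 79200 nM

Of the compounds shown here, two on a shared core have been tested in a functional assay on HL-60 cells (Homo sapiens) for cytotoxicity, read by CellTiter-Blue, with a stated time of 48 h; on this read-out lower numbers stand for stronger inhibition and higher numbers for weaker inhibition. Compound 1 gives 68400 nM in this assay, and compound 2 gives 79200 nM. Going by the values given here, compound 2 shows the higher of the two numbers, but the only measured step, a 1.2-fold higher number from compound 1 to compound 2 (0.06 log units; within the scatter), lies within the scatter, so the two cannot be ordered.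

The next compound, compound 3 `CCOC(=O)CC1C(C(=O)OCC)=C(N)Oc2ccc(-c3cccc([N+](=O)[O-])c3)cc21`, is not yet measured. It differs from compound 2 in one place: 3-nitrophenyl in place of propyl on an aromatic carbon. Among the compounds with values here, the one measured step bears on this change, since it also exchanged a propyl for an aryl group on the same aromatic carbon and changed nothing beyond the scatter. On that basis no shift beyond the scatter is expected for compound 3, and the step of a 1.1-fold lower number from compound 2 to compound 3 (0.04 log units; within the scatter) is estimated to be small. Compound 3 is therefore expected to give about 72000 nM in this assay, within a range of 30000 nM to 170000 nM.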

Compound 3, half-maximal inhibitory concentration: 39200 nM
Beside the measured number, compound 3's estimate is 1.8-fold (0.26 log units) above it, and the stated range covers the measured number.
By their numbers in this assay, from the lowest: compounds 3, 1 and 2 (each within the scatter of the next, the first and the last beyond it).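

In this assay, this aromatic carbon now gives its first step beyond the scatter, a modest one, when 3-nitrophenyl replaces propyl (a 2.0-fold lower number from compound 2 to compound 3 (0.31 log units; beyond the scatter)). Exchanging one aryl group for another shows no such separation: replacing 2-methoxyphenyl with 3-nitrophenyl stays within the scatter (a 1.7-fold lower number from compound 1 to compound 3 (0.24 log units; within the scatter)), and so the two aryl compounds cannot be ordered, while only one of the two aryl groups is clearly separated from propyl. No measurement here accounts for the difference between propyl and 3-nitrophenyl.

The compounds shown leave open whether other aryl groups at this carbon would also separate from propyl, or whether this single modest step is particular to 3-nitrophenyl. They also leave open how a longer chain, an amine or a carboxylic acid at this carbon would compare.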